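From oxan-2-yl to oxan-3-yl on a shared core

A few compounds are considered here, and "the series" means these few. Any claim that something is new, unique, unknown or untested is made for them only; others in the source may bear on it.

In an in vitro ADME assay on microsomes from liver (Homo sapiens) for metabolic stability (a higher number here means faster removal of the compound, a lower number slower removal), compound 1 (`CC(C)Nc1nccc(-c2c[nH]nc2C2CCCCO2)n1`) gives 0.021 mL/min/kg and stands close to compound 3 (`OC1CCCC(c2n[nH]cc2-c2ccnc(NC3CCCC3)n2)C1`), which gives 0.015 mL/min/kg within the scatter of compound 1. Compound 2 (`Clc1ccc(-c2n[nH]cc2-c2ccnc(NC3CC3)n2)cc1`) gives 0.096 mL/min/kg and is the only one of the three beyond the scatter of compound 1, on the side of faster removal.

Compound 4 (`CC(C)Nc1nccc(-c2c[nH]nc2C2CCCOC2)n1`) has not yet been measured. It differs from compound 1 in one place: oxan-3-yl in place of oxan-2-yl on an aromatic carbon with oxan-3-yl in place of oxan-2-yl on an aromatic carbon. The two have the same atoms, joined differently. For the measured compounds named here, no pair of measured compounds differs in only one place, so the data offer no direct precedent for this change in this assay. The expectation therefore rests on compound 1 at 0.021 mL/min/kg as the closest reference, and no step beyond the scatter is expected. The estimated step is a 1.2-fold higher number from compound 1 to compound 4 (0.08 log units; within the scatter) and no firm direction is claimed for it. Compound 4 is expected to give about 0.025 mL/min/kg with an estimated range from 0.012 mL/min/kg to 0.052 mL/min/kg in this measurement.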

Compound 4, clearance: 0.034 mL/min/kg
Compound 4: the middle estimate sits 1.4-fold (0.13 log units) below what was measured, within the range that was stated.
By their numbers in this assay, from the lowest: compounds 3, 1 and 4 (each within the scatter of the next, the first and the last beyond it); then compound 2.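

For the compounds shown here, on the five-membered aromatic ring with 2 nitrogen, at the aromatic carbon next to the ring nitrogen, oxan-3-yl in place of oxan-2-yl gives in this assay the first one-place comparison in this set (a 1.6-fold higher number from compound 1 to compound 4 (0.21 log units; within the scatter)). The step shows that, at this position and on the core of compound 1, these two groups, with the same atoms joined differently, cannot be told apart in this measurement. Nothing available bears on why the two oxane groups read alike here.

From the compounds shown here alone, it remains open whether a piperidine ring or a longer chain such as methoxypropyl at this position would also stay within the scatter of compound 1. Going by these compounds, it is equally open whether oxan-3-yl in place of oxan-2-yl would read the same on a different core.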